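A few compounds are considered here, and "the series" means these few. Any claim that something is new, unique, unknown or untested is made for them only; others in the source may bear on it.

The measured compounds:

Compound 1, `O=C1Nc2ccccc2C1(c1c[nH]c2ccccc12)c1c[nH]c2ccccc12`, gives 8700 nM in a functional assay on DU-145 cells (Homo sapiens) for cytotoxicity, read by MTT assay, with a stated time of 48 h; on this read-out higher numbers stand for weaker inhibition and lower numbers for stronger inhibition.

Compound 2, `COc1ccc2[nH]cc(C3(c4c[nH]c5ccc(OC)cc45)C(=O)Nc4ccccc43)c2c1`, gives 2200 nM in this assay.

Compound 3, `O=C1Nc2ccc(F)cc2C1(c1c[nH]c2ccccc12)c1c[nH]c2ccccc12`, gives 12800 nM in this assay.

Compound 1 and compound 2 differ in more than one place, and the difference between the two cores is not broken down here. Their values show that compound 2 has the lowest number of the three, and its gaps to compound 1 and to compound 3 are both beyond the usual scatter of repeated measurements. Compound 3 differs from compound 1 by a single change, (fluoro in place of hydrogen on an aromatic carbon), and that change made a 1.5-fold higher number from compound 1 to compound 3 (0.17 log units; within the scatter). In plain terms, adding the fluoro to compound 1 left the read-out essentially where it was.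

Compound 4, `COc1ccc2[nH]cc(C3(c4c[nH]c5ccc(OC)cc45)C(=O)Nc4ccc(F)cc43)c2c1`, has not yet been measured. It differs from compound 2 by fluoro in place of hydrogen on an aromatic carbon, which is the same change, at the same place, that turns compound 1 into compound 3. Among the measured compounds shown here, the one measured example of this change is the only guide to the step that compound 4 may take. On that basis the step from compound 2 to compound 4 is expected to be small, a 1.3-fold higher number from compound 2 to compound 4 (0.12 log units; within the scatter), resting on the step seen in a 1.5-fold higher number from compound 1 to compound 3 (0.17 log units; within the scatter). Compound 4 is therefore estimated at 2900 nM in this assay. For compound 4 the expected range runs from 1400 nM to 6000 nM.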

Compound 4, half-maximal inhibitory concentration: 3600 nM
The estimate for compound 4 lay 1.2-fold (0.09 log units) below the measured number; measured number inside the range.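

Putting fluoro in place of hydrogen on the core of compound 2 gave a 1.6-fold higher number from compound 2 to compound 4 (0.21 log units; within the scatter) in this assay, so on this second core the change again stays inside the normal spread of repeated measurements. Set beside the earlier example, the change looks the same on both cores: the same change on two cores in this assay, a 1.5-fold higher number (0.17 log units; within the scatter) from compound 1 to compound 3 and a 1.6-fold higher number (0.21 log units; within the scatter) from compound 2 to compound 4, 1.1-fold (0.05 log units) apart, within the scatter of two such steps. This shows that, in these two pairs, the fluoro carried from one core to the other without altering the picture, and that the result on the first core was a fair guide to the result on the second; it does not show that fluoro has a real effect of any size in either pair, and two pairs are too few to promise the same outcome on a third core.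

The compounds shown test only fluoro at this one place on the ring, so it remains open whether a larger or very different group there, such as a chlorine atom, a nitrile, an amine or a carboxylic acid, would also leave the read-out unmoved. Going by these compounds, it also remains open whether fluoro placed elsewhere on the ring would behave as it does here.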